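The source may report more compounds than this note shows. Statements on the series, on what has been measured and on what is new or still open speak of the compounds shown alone.

Compound 2 `CC(Cc1ccccc1-c1cccnc1)C1=NCCN1` carries a pyridin-3-yl ring on the shared core. In an assay on PC-12 cells for displacement of a labelled ligand from Nischarin (Rattus norvegicus) (on this read-out lower numbers stand for stronger inhibition and higher numbers for weaker inhibition), compound 2 gives only a limit of the assay, > 1000 nM, and not a measured number. Compound 4 `CC(Cc1ccccc1-c1cccc(O)c1)C1=NCCN1` differs from compound 2 in a single place: 3-hydroxyphenyl in place of pyridin-3-yl on an aromatic carbon. Two measured compounds give some footing. Compound 1 `C[C@H](Cc1ccccc1-c1ccccc1)C1=NCCN1` and compound 3 `C[C@@H](Cc1ccccc1-c1ccccc1)C1=NCCN1` both carry a plain phenyl ring on the same core and are built from the same atoms and bonds. In this assay compound 1 gives 2240 nM, whereas compound 3 gives 97.7 nM, so the step of a 23-fold lower number from compound 1 to compound 3 (1.36 log units; beyond the scatter) is large, and that whole step rests on (the fact that compounds 1 and 3 differ only in the configuration as drawn), not on any change of the attached ring. Among the compounds with values here, no measured pair shows how exchanging one ring for another moves the value, and for compound 2 itself there is only the limit of > 1000 nM in this assay, at which 1 of the 3 values shown sits, to go on. The step from compound 2 to compound 4 is therefore expected to be moderate and uncertain in direction, as an at least 1.2-fold lower number from compound 2 to compound 4 (0.09 log units; that floor lies within the scatter) expresses. Compound 4 is estimated at 800 nM, with a likely range from 150 nM to 4000 nM.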

Compound 4, inhibition constant: > 1000 nM
Compound 4: only a limit was reported (the forecaster's own chance of this, stated with the estimate: 40%); middle value at least 1.2-fold (0.09 log units) away from the limit.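

In this assay compound 4, like compound 2, gives only a limit and not a number, and the step between these two compounds cannot be read. The compounds shown leave open how exchanging pyridin-3-yl for 3-hydroxyphenyl moves the value, and how either ring would fare in each of the two configurations that separate compound 1 from compound 3.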